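The compounds below may be only part of what the source reports. "The series", "measured", "known", "first", "only" and "open" are said of these compounds alone.

Compound 1 `C[Se]/C(=N\C(=O)c1cccs1)NC(=O)c1cccs1` gives > 100000 nM
Compound 2 `CS/C(=N\C(=O)c1cccs1)NC(=O)c1cccs1` gives > 100000 nM
Compound 3 `CS/C(=N\C(=O)c1cc(-c2ccccc2)nc2ccccc12)NC(=O)c1cc(-c2ccccc2)nc2ccccc12` gives > 100000 nM

All three readings come from a functional assay on K562 cells (Homo sapiens) for cytotoxicity, read by MTT assay, with a stated time of 72 h; a higher number here means a weaker inhibitor of growth, a lower number a stronger inhibitor of growth. For compound 1 the reading > 100000 nM is a limit of the assay, not a number. For compound 2 the reading > 100000 nM is likewise a limit. For compound 3 the reading > 100000 nM is a limit as well.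

Compound 1 and compound 2 share one core and differ in a single place: a group of 2 heavy atoms (1 carbon, 1 selenium; no ring) in place of a group of 2 heavy atoms (1 carbon, 1 sulfur; no ring), on a carbon with a double bond to nitrogen. The resulting step that the two limits leave unreadable from compound 2 to compound 1 cannot be sized because both readings sit at the limit of > 100000 nM in this assay, at which 3 of the 3 values shown sit. Compound 3 carries a different core from compound 2; the difference between the two cores is not broken down here.

Compound 4 `C[Se]/C(=N\C(=O)c1cc(-c2ccccc2)nc2ccccc12)NC(=O)c1cc(-c2ccccc2)nc2ccccc12` has not yet been measured. It differs from compound 3 by a group of 2 heavy atoms (1 carbon, 1 selenium; no ring) in place of a group of 2 heavy atoms (1 carbon, 1 sulfur; no ring), on a carbon with a double bond to nitrogen, and since the surroundings of the exchanged group are the same in both pairs, this is the same change that turns compound 2 into compound 1. For the measured compounds named here, for compound 4 the step from compound 3 is expected to be a step that the limit leaves unreadable from compound 3 to compound 4, resting on compound 3 sitting at the limit of > 100000 nM in this assay, at which 3 of the 3 values shown sit, and on the only measured example of this change, a step that the two limits leave unreadable from compound 2 to compound 1, giving no readable size. The most likely outcome is that compound 4 also returns only a limit in this assay. The estimate for compound 4 is therefore 150000 nM, with a range from 40000 nM to 600000 nM.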

Compound 4, concentration for total growth inhibition: 30600 nM
Compound 4: the middle estimate sits 4.9-fold (0.69 log units) above what was measured; the whole stated range lies above it.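

In this assay, putting the selenium-containing group in place of methylsulfanyl, on a carbon with a double bond to nitrogen, gives an at least 3.2-fold lower number from compound 3 to compound 4 (0.51 log units; beyond the scatter); the true step may be larger, and this is the only place in the series where the change can be sized. The same change on the other core, going from compound 2 to compound 1, cannot be sized, because both of those readings are limits and not numbers: the limit of > 100000 nM in this assay, at which 3 of the 4 values shown sit. So the lower number is shown on the core of compound 3 alone, and nothing here shows whether it carries over to the core of compound 1, where the change might have had the same effect, a different effect or none, and the reason for the step on the core of compound 3 stays unknown.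

The compounds shown leave open how other groups would read on the same carbon, for example methoxy, an amine or a longer chain such as ethylsulfanyl, and so whether the gain belongs to selenium itself. They also leave open whether a core other than these two would respond to the exchange as the core of compound 3 does.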